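Lipophilicity notes on a fused pyridine series

The source may report more compounds than this note shows. Statements on the series, on what has been measured and on what is new or still open speak of the compounds shown alone.

Measured so far:
compound 1, `CNC(=O)c1cc(-c2cnc(NCc3c(F)ccc4c3CCO4)c3cn[nH]c(=O)c23)n(C)n1` – 2.1
compound 2, `Cc1nc(CN(C)C)ccc1-c1cnc(NCc2c(F)ccc3c2CCO3)c2cn[nH]c(=O)c12` – 2

In a physicochemical assay for lipophilicity, using the shake flask method, in phosphate buffer, measured as octanol-water partition, with a stated time of 30 min, at pH 7.4 (on this read-out lower numbers stand for lower lipophilicity and higher numbers for higher lipophilicity), compound 1 gives 2.1 and compound 2 gives 2. Within the data shown here, compound 2 holds the lower of the two numbers, but the only measured step, a number 0.10 log units lower from compound 1 to compound 2 (within the scatter), is within the scatter, so the two values cannot be told apart.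

Compound 3, `CC(=O)N1CCC(c2cnc(NCc3c(F)ccc4c3CCO4)c3cn[nH]c(=O)c23)CC1`, is not yet measured. Relative to compound 2 the change is 1-acetylpiperidin-4-yl in place of 6-((dimethylamino)methyl)-2-methylpyridin-3-yl on an aromatic carbon. Among the measured compounds shown here, the one measured step, a number 0.10 log units lower from compound 1 to compound 2 (within the scatter), swaps one aromatic group for another at the same aromatic carbon and is within the scatter; it bears only loosely on the present change, which brings in a non-aromatic ring and a carbonyl. For the measured compounds named here, no measured step covers such a swap, so the expectation rests on little. For compound 3 the estimated step is a number 0.30 log units lower from compound 2 to compound 3 (within the scatter), expected to be small and toward the lower side. The estimate for compound 3 in this assay is 1.7, with a range of 1.1 to 2.3.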

Compound 3, distribution coefficient: 2.9
For compound 3 the middle estimate is 1.20 log units below the measured one; the measured number lies above the stated range.
By their numbers in this assay, from the lowest: compounds 2 and 1 (each within the scatter of the next); then compound 3.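

Replacing 6-((dimethylamino)methyl)-2-methylpyridin-3-yl with 1-acetylpiperidin-4-yl on this aromatic carbon of the shared core gives a number 0.90 log units higher from compound 2 to compound 3 (beyond the scatter) in this assay, and a number 0.80 log units higher from compound 1 to compound 3 (beyond the scatter) when the same group replaces 1-methyl-3-(methylcarbamoyl)-1H-pyrazol-5-yl. Among these compounds, compound 1 and compound 2, which carry two different aromatic groups here, lie within the scatter of each other, so this is the first sign that the substituent on this carbon can shift the read-out beyond the scatter. No measurement shown accounts for the size of this step.

Both steps exchange an aromatic ring for a non-aromatic ring and bring in the acetyl group at once, so the compounds shown do not separate the two changes. A free piperidine amine or a plain cyclohexyl group on this carbon would help to separate them.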